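Taking the tert-butyl group off compound 1

The compounds below may be only part of what the source reports. "The series", "measured", "known", "first", "only" and "open" are said of these compounds alone.

Going by the values given here, in an ADME assay on cells (Peritoneal macrophage, Mus musculus) for cytotoxicity, read by MTT assay, with a stated time of 24 h (on this read-out lower numbers stand for higher toxicity in this test and higher numbers for lower toxicity in this test), compound 1 `CC(C)(C)c1ccc(N/C(=N\C(=O)c2ccccc2)NCc2ccccc2)cc1` gives 1120000 nM, the higher of the two numbers available so far. Among the compounds with values here, compound 2 `O=C(/N=C(/NCc1ccccc1)Nc1ccc(C(F)(F)F)cc1)c1ccccc1` gives 18600 nM, which makes it the only and therefore nearest neighbour of compound 1. Within the data shown here, the one measured step, a 60-fold lower number from compound 1 to compound 2 (1.78 log units; beyond the scatter), is large and lies beyond the scatter; in it, tert-butyl gives way to trifluoromethyl.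

Compound 3 `O=C(/N=C(/NCc1ccccc1)Nc1ccccc1)c1ccccc1` has not yet been measured. It differs from compound 1 by hydrogen in place of tert-butyl on an aromatic carbon, with hydrogen in place of tert-butyl on an aromatic carbon of a six-membered aromatic ring of carbon only, para to a large group. Among the measured compounds shown here, only the step to compound 2 bears on this change, as tert-butyl leaves there too, although a different group enters. The data do not show how hydrogen alone would behave, so that single step is a loose guide. A large fall in this assay, beyond the scatter, is expected, and the expected change is a 7.5-fold lower number from compound 1 to compound 3 (0.87 log units; beyond the scatter). For compound 3 the estimated value is 150000 nM, with the measurement expected between 20000 nM and 900000 nM.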

Compound 3, half-maximal cytotoxic concentration: 35900 nM
Beside the measured number, compound 3's estimate is 4.2-fold (0.62 log units) above it; measured number inside the range.
By their numbers in this assay, from the lowest: compounds 2 and 3 (each within the scatter of the next); then compound 1.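

In this assay hydrogen in place of tert-butyl gives a 31-fold lower number from compound 1 to compound 3 (1.49 log units; beyond the scatter) and this shows that the large fall seen earlier does not depend on trifluoromethyl entering, since it also appears when no heavy atom enters at all. Trifluoromethyl and hydrogen on this aromatic carbon cannot be told apart, with a 1.9-fold higher number from compound 2 to compound 3 (0.29 log units; within the scatter) lying within the scatter, so among these three compounds tert-butyl is the one group that stands apart from the other two. Nothing measured here accounts for why compound 1 stands apart in this way.

The compounds shown leave open whether other carbon groups on this aromatic carbon, such as methyl or isopropyl, would read close to compound 1 or close to compound 2 and compound 3, and where a methoxy group or an amine in the same place would fall. They also leave open whether the step from tert-butyl to hydrogen keeps its size when another part of the core of compound 1 is changed.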